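From chloro to iodo on a shared core

A few compounds are considered here, and "the series" means these few. Any claim that something is new, unique, unknown or untested is made for them only; others in the source may bear on it.

Compound 1 `Oc1ccc2cc(-c3ccc(O)c4ncccc34)oc2c1` gives 15.8 10^-6 cm/s
Compound 2 `Oc1ccc2cc(-c3cc(Cl)c(O)c4ncccc34)oc2c1` gives 17.9 10^-6 cm/s

In an ADME assay for permeability, using PAMPA, with a stated time of 10 h, tested at 100 ug/mL (a lower number here means that the compound crosses the layer more slowly, a higher number that the compound crosses the layer faster), compound 2 stands within the scatter of compound 1. Compound 3 `Oc1ccc2cc(-c3cc(I)c(O)c4ncccc34)oc2c1` keeps the same core and carries iodo in place of chloro on an aromatic carbon, ortho to a hydroxy group. Among the measured compounds shown here, the only measured step that bears on this swap, chloro in place of hydrogen, is a 1.1-fold higher number from compound 1 to compound 2 (0.05 log units; within the scatter) and it is small. For the measured compounds named here, no measured step involves iodo, so no shift beyond the scatter, in either direction, is expected (a 1.0-fold higher number from compound 2 to compound 3 (0.00 log units; within the scatter)). For compound 3 the estimated value is 18 10^-6 cm/s with 10 10^-6 cm/s to 32 10^-6 cm/s as the expected range.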

Compound 3, apparent permeability: 16.6 10^-6 cm/s
Beside the measured number, compound 3's estimate is 1.1-fold (0.04 log units) above it; measured number inside the range.
By their numbers in this assay, from the lowest: compounds 1, 3 and 2 (each within the scatter of the next).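

In this assay, this aromatic carbon, ortho to a hydroxy group, has now been seen with iodo as well as chloro and hydrogen, and the three remain within the scatter. The swap gives (a 1.1-fold lower number from compound 2 to compound 3 (0.03 log units; within the scatter)), and iodo against hydrogen gives (a 1.1-fold higher number from compound 1 to compound 3 (0.02 log units; within the scatter)). No supporting measurement bears on the cause of this flat result.

On these data alone, whether an amine or a carboxylic acid at this place would also stay within the scatter remains open. So does whether iodo would behave the same way on another core.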